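Swapping the Amide Phenyl for a Hydroxypropyl Chain

This account rests on a few compounds, and the source may have more. Where it says the series, first, only, none or still open, it means among the compounds named here.

Of the compounds shown here, three sharing one core have been measured in an assay on HEK293 cells for agonist activity at transient receptor potential cation channel subfamily M member 8 (Homo sapiens), read by fluorescence and calcium flux, with a stated time of 15 min; a lower number here means that less compound is needed, a higher number that more compound is needed for the effect. Compound 1 `Cc1ccc(OCC(=O)N(Cc2cccs2)c2ccccn2)cc1` gives 200 nM, compound 2 `CCCN(Cc1cccs1)C(=O)COc1ccc(C)cc1` gives 40 nM, and compound 3 `Cc1ccc(OCC(=O)N(Cc2cccs2)c2ccccc2)cc1` gives 23 nM. Compound 3 stands at the favourable end of these numbers: an 8.7-fold lower number from compound 1 to compound 3 (0.94 log units; beyond the scatter), while its gap to compound 2 lies within the scatter. The change to compound 4 `Cc1ccc(OCC(=O)N(CCCO)Cc2cccs2)cc1` is 3-hydroxypropyl in place of phenyl on an amide-type nitrogen. The measured step that bears on it is a 1.7-fold lower number from compound 2 to compound 3 (0.24 log units; within the scatter), so a phenyl and a plain propyl chain on this nitrogen give numbers within the scatter of each other. Within the data shown here, no measured step covers the added hydroxyl. The step to compound 4 is therefore expected to be modest, a 2.6-fold higher number from compound 3 to compound 4 (0.42 log units; beyond the scatter). Compound 4 is expected at 60 nM, within 20 nM to 200 nM.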

Compound 4, half-maximal effective concentration: 3000 nM
The estimate for compound 4 lay 50-fold (1.70 log units) below the measured number, and the stated range ends below it.
By their numbers in this assay, from the lowest: compounds 3 and 2 (each within the scatter of the next); then compound 1; then compound 4.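

On this amide-type nitrogen, the hydroxy group on the chain is enough for a large change in this assay: with the plain propyl chain kept, hydroxy in place of hydrogen gives (a 75-fold higher number from compound 2 to compound 4 (1.88 log units; beyond the scatter)). The 3-hydroxypropyl chain also compares poorly with both aromatic groups, phenyl (a 130-fold higher number from compound 3 to compound 4 (2.12 log units; beyond the scatter)) and pyridin-2-yl (a 15-fold higher number from compound 1 to compound 4 (1.18 log units; beyond the scatter)), so this nitrogen accepts those groups and a plain propyl far better than this chain. Nothing measured here explains the effect of the hydroxy group.

Still open, as far as these compounds go, is whether a 3-methoxypropyl or 3-aminopropyl chain would give a similar number. A hydroxy group on a shorter or longer chain also remains untested in the compounds shown.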